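Replacing the nitrile by an amino group on the shared core

The source may hold more compounds than are shown below. What is called first, only, known or untested is meant among the compounds shown, and "the series" means these compounds.

Two compounds share one core and differ only in the group on one aromatic ring. Compound 1 `CC(C)(C)c1cc(NC(=O)Nc2ccc(Cl)cc2)n(-c2ccc(OC(F)(F)F)cc2)n1` carries a trifluoromethoxy group there; in an assay on isolated protein for inhibition of STE20-like serine/threonine-protein kinase (Homo sapiens), read by thermal shift assay, tested at 10 uM (a higher number here means that the compound stabilises the target more against heat, a lower number that the compound stabilises the target less), compound 1 gives 0.2 degrees C. Compound 2 `CC(C)(C)c1cc(NC(=O)Nc2ccc(Cl)cc2)n(-c2ccc(C#N)cc2)n1` carries a cyano group in the same place, and in this assay compound 2 gives 1.6 degrees C. Compound 2 therefore stands highest of the two numbers; the step of a number 1.4 degrees C higher from compound 1 to compound 2 (beyond the scatter) sets it apart from compound 1.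

Compound 3 `CC(C)(C)c1cc(NC(=O)Nc2ccc(Cl)cc2)n(-c2ccc(N)cc2)n1` is not yet measured. It differs from compound 2 by amino in place of cyano on an aromatic carbon. Going by the values given here, the only measured step, from compound 1 to compound 2, concerns a different exchange on the same aromatic carbon and was modest in size. Among the compounds with values here, no measured step shows an amino group, so nothing here tells the direction of the new change. The estimated step of a number 0.60 degrees C lower from compound 2 to compound 3 (within the scatter) is expected to stay close to the scatter. For compound 3 the estimated value in this assay is 1 degrees C, with a range from -0.2 degrees C to 2.2 degrees C.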

Compound 3, shift of the target's melting temperature: 5.6 degrees C
For compound 3 the middle estimate is 4.6 degrees C below the measured one; the measured number lies above the stated range.
By their numbers in this assay, from the lowest: compound 1; then compound 2; then compound 3.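

This position tolerates more change in the read-out than the first pair suggested: the exchange of cyano for amino gives a number 4.0 degrees C higher from compound 2 to compound 3 (beyond the scatter) in this assay, and the exchange of trifluoromethoxy for amino gives a number 5.4 degrees C higher from compound 1 to compound 3 (beyond the scatter), so compound 3 stands clearly above both others. Compared with the nitrile, the amino group has one heavy atom rather than two and brings the count of hydrogen-bond donors from 0 to 1, but these counts only describe the change and a single exchange cannot show whether either of them matters. Nothing available explains why the amino group stands out in this series.

From the compounds shown here alone, it remains open whether the rise needs a free amino group or would also appear with a close relative in the same place, such as a hydroxyl group, a methylamino group or an acetylamino group. Going by these compounds, it is also open whether the same exchange would give a similar step on a different core, since this one comparison rests on a single shared core.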